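A few compounds are considered here, and "the series" means these few. Any claim that something is new, unique, unknown or untested is made for them only; others in the source may bear on it.

Measured so far, in a functional assay on SV5A8 cells (Homo sapiens) for cytotoxicity; a higher number here means a weaker inhibitor, a lower number a stronger inhibitor:
compound 1, `Cc1ccc(CN2CCC(C(=O)Nc3ccc(CNc4nc(N(C)C)nc5cc(C)ccc45)cc3)CC2)cc1`: > 4150 nM, a limit of the assay
compound 2, `COc1ccc(CN2CCC(C(=O)Nc3ccc(CNc4nc(N(C)C)nc5cc(C)ccc45)cc3)CC2)cc1`: > 6180 nM, a limit of the assay
compound 3, `Cc1ccc2c(NCc3ccc(NC(=O)C4CCN(Cc5cccc(F)c5)CC4)cc3)nc(N(C)C)nc2c1`: > 4170 nM, a limit of the assay

Compound 3 stands at a limit, (the limit of > 4170 nM in this assay, at which 1 of the 3 values shown sits), and no number is known for it. The two other compounds stand at limits of their own, the limit of > 4150 nM in this assay, at which 1 of the 3 values shown sits, and (the limit of > 6180 nM in this assay, at which 1 of the 3 values shown sits), so none of the three values is a number. The step from compound 1 to compound 3 is a step that the two limits leave unreadable from compound 1 to compound 3, the step from compound 2 to compound 3 is a step that the two limits leave unreadable from compound 2 to compound 3, and the step from compound 1 to compound 2 is a step that the two limits leave unreadable from compound 1 to compound 2; all three are hidden by the limits.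

Compound 4, `Cc1ccc2c(NCc3ccc(NC(=O)C4CCN(Cc5ccc(F)cc5Cl)CC4)cc3)nc(N(C)C)nc2c1`, differs from compound 3 in one place: 2-chloro-4-fluorophenyl in place of 3-fluorophenyl on a saturated chain carbon bound to an amine nitrogen in a ring. Going by the values given here, no measured step bears readably on this change, since every value in this assay is a limit, and no direction can be read from them. Compound 4 is therefore expected to sit at or beyond the limit as well, with the step from compound 3 to compound 4 expected as a step that the limit leaves unreadable from compound 3 to compound 4. For compound 4 the estimate in this assay is 9000 nM, with a range from 4000 nM to 40000 nM.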

Compound 4, half-maximal inhibitory concentration: > 5910 nM
Compound 4: no number, only a limit (the forecaster's own chance of this, stated with the estimate: 80%); the middle value does not contradict the limit.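

In this assay compound 4 gives > 5910 nM, a limit of the assay and not a number. None of the steps to compound 4 from compound 1, compound 2 or compound 3 can be read. The four compounds leave open what their actual values in this assay are, and whether changing the aromatic group on the saturated chain carbon bound to an amine nitrogen in a ring alters them at all.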